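Three compounds at the limit, a fourth still to test

A few compounds are considered here, and "the series" means these few. Any claim that something is new, unique, unknown or untested is made for them only; others in the source may bear on it.

Values in an assay on cells for inhibition of Nicotinamide N-methyltransferase (Homo sapiens), with stated times of 10 min and 30 min; a lower number here means a stronger inhibitor, a higher number a weaker inhibitor:
- compound 1 `COC(=O)c1cccc(CN(CCCC(=O)O)C[C@H]2O[C@@H](n3cnc4c(N)ncnc43)[C@H](O)[C@@H]2O)c1`: > 250000 nM, a limit of the assay
- compound 2 `NC(=O)CCCN(Cc1cccc(C(=O)O)c1)C[C@H]1O[C@@H](n2cnc3c(N)ncnc32)[C@H](O)[C@@H]1O`: > 250000 nM, a limit of the assay
- compound 3 `NC(=O)CCCCN(Cc1cccc(C(=O)O)c1)C[C@H]1O[C@@H](n2cnc3c(N)ncnc32)[C@H](O)[C@@H]1O`: > 250000 nM, a limit of the assay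

Compound 3 stands only at a limit; no number is known for it, and the same holds for the other two compounds, all three sitting at the limit of > 250000 nM in this assay, at which 3 of the 3 values shown sit. Going by the values given here, the one single-point step in the set, a step that the two limits leave unreadable from compound 2 to compound 3, is therefore unreadable in size and direction.

Compound 4 `Nc1ncnc2c1ncn2[C@@H]1O[C@H](CN(CCCC(=O)O)Cc2cccc(C(=O)O)c2)[C@@H](O)[C@H]1O` differs from compound 3 by carboxy in place of carbamoylmethyl on a saturated chain carbon, three bonds along the chain from an amine nitrogen. Among the compounds with values here, no measured step bears readably on this change: the only step available, from one limit to another, gives no size to work from, and none of the three compounds gives a number that would anchor a direction.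

With nothing but limits in hand, compound 4 is expected to behave like compound 3 and to return a limit rather than a number. The estimate for compound 4 in this assay is 250000 nM, with a range from 100000 nM to 1000000 nM. The step this estimate implies, a number no higher from compound 3 to compound 4 (the limit leaves the size open), is expected to stay within the scatter, given that compound 3 shows > 250000 nM as a limit only.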

Compound 4, half-maximal inhibitory concentration: > 250000 nM
Compound 4 was reported as a limit; the forecaster's own chance of this, stated with the estimate: 85%; the middle value lies on the limit itself.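

In this assay compound 4 gives > 250000 nM, a limit of the assay and not a number. Going by these compounds alone, no step from compound 1, compound 2 or compound 3 to compound 4 can be read, because all values sit at one limit: the limit of > 250000 nM in this assay, at which 4 of the 4 values shown sit. The compounds shown leave open whether any of these changes alters inhibition at all, and in which direction.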